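Amide variation on the hexafluoro carbinol naphthalene series

This account rests on a few compounds, and the source may have more. Where it says the series, first, only, none or still open, it means among the compounds named here.

Compound 1 `CC(=O)Nc1c(C(O)(C(F)(F)F)C(F)(F)F)ccc2ccccc12` gives 18 nM in an assay on LtK cells with ATP-sensitive inward rectifier potassium channel 11 (Homo sapiens) as the target; a lower number here means that less compound is needed, a higher number that more compound is needed for the effect. Compound 2 `COCC(=O)Nc1c(C(O)(C(F)(F)F)C(F)(F)F)ccc2ccccc12` gives 213 nM, the highest of the two numbers measured; the step of a 12-fold higher number from compound 1 to compound 2 (1.07 log units; beyond the scatter) is the only one available. Compound 3 `Cc1ccc(C(=O)Nc2c(C(O)(C(F)(F)F)C(F)(F)F)ccc3ccccc23)cc1` carries the change (4-methylphenyl in place of methoxymethyl on a carbonyl carbon). Going by the values given here, the single measured step says only that adding methoxy on the chain hurt; no step with an aryl amide is known, so the expectation is weakly founded. The expected step toward a lower number is roughly a 3.6-fold lower number from compound 2 to compound 3 (0.55 log units; beyond the scatter) with wide uncertainty. Compound 3 is estimated at 60 nM, between 15 nM and 300 nM.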

Compound 3, half-maximal effective concentration: 76 nM
Estimate against measurement, compound 3: 1.3-fold (0.10 log units) below; low and high end bracket the measured number.
By their numbers in this assay, from the lowest: compound 1; then compound 3; then compound 2.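

In this assay the carbonyl carbon accepts an aromatic ring: 4-methylphenyl in place of methoxymethyl gives a 2.8-fold lower number from compound 2 to compound 3 (0.45 log units; beyond the scatter) and so recovers part of the loss seen with methoxymethyl. Against methyl the same group still gives a 4.2-fold higher number from compound 1 to compound 3 (0.63 log units; beyond the scatter) and leaves compound 1 with the lowest number of the three. Nothing at hand accounts for these differences. Still open, as far as these compounds go, is whether an unsubstituted phenyl or a longer alkyl chain such as ethyl on the carbonyl carbon would match methyl. Also open, from the compounds shown here alone, is how an amine on that chain would compare with methoxymethyl.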